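This account rests on a few compounds, and the source may have more. Where it says the series, first, only, none or still open, it means among the compounds named here.

Compound 1 `CNC(=O)CCc1ccncc1-c1ccc2ccccc2c1`: > 10000 nM
Compound 2 `NC(=O)/C=C/c1ccncc1-c1ccc2ccccc2c1`: > 10000 nM

Both entries are limits of a functional assay on MCF7 cells (Homo sapiens) for inhibition, read by sulforhodamine B assay, with a stated time of 72 h (on this read-out higher numbers stand for weaker inhibition of growth and lower numbers for stronger inhibition of growth), not numbers, so compound 2 has no exact place on the scale. For the measured compounds named here, the one measured step, a step that the two limits leave unreadable from compound 1 to compound 2, has no readable size and gives no guide to direction. Compound 3 `O=C(O)CCc1ccncc1-c1ccc2ccccc2c1` carries the change 2-carboxyethyl in place of 2-carbamoylethenyl on an aromatic carbon. Going by the values given here, the only guide is the limit of > 10000 nM in this assay, at which 2 of the 2 values shown sit, so no step beyond the scatter is expected in this assay. The estimated change is a step that the limit leaves unreadable from compound 2 to compound 3. The value expected for compound 3 is 15000 nM, with an estimated range of 8000 nM to 40000 nM.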

Compound 3, concentration for 50% growth inhibition: > 10000 nM
Compound 3: a limit, no number; the forecaster's own chance of this, stated with the estimate: 90%; the middle value does not contradict the limit.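

For the compounds shown here, compound 1, compound 2 and compound 3 all give limits rather than numbers, and no step between them can be read. Going by these compounds, how strongly each of the three inhibits growth, and whether any change of group alters that, stays open.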